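Alpha-1 series: isopropyl at the fused-ring position

The compounds below may be only part of what the source reports. "The series", "measured", "known", "first", "only" and "open" are said of these compounds alone.

Compound 2 `O=C1NCCN1CCN1CCC(c2cn(-c3ccc(F)cc3)c3cc(F)ccc23)CC1` gives the lowest of the two numbers in an assay on cell membranes for displacement of a labelled ligand from Adrenergic receptor alpha-1 (Rattus norvegicus) (a higher number here means a weaker inhibitor, a lower number a stronger inhibitor), at 2.2 nM; its nearest neighbour, compound 1 `O=C1NCCN1CCN1CCC(c2cn(-c3ccc(F)cc3)c3cc(C(F)(F)F)ccc23)CC1`, gives 33 nM. The step of a 15-fold lower number from compound 1 to compound 2 (1.18 log units; beyond the scatter) is the only one measured that touches this position. Compound 3 `CC(C)c1ccc2c(C3CCN(CCN4CCNC4=O)CC3)cn(-c3ccc(F)cc3)c2c1` differs from compound 2 by isopropyl in place of fluoro on an aromatic carbon. That earlier step went from a three-fluorine group to a single fluorine; here a three-carbon group enters in place of the fluorine, so a rise in this assay is expected, though its size is uncertain. Compound 3 is estimated at 20 nM (range 5 nM to 80 nM), a step of a 9.1-fold higher number from compound 2 to compound 3 (0.96 log units; beyond the scatter) from compound 2.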

Compound 3, half-maximal inhibitory concentration: 250 nM
Estimate against measurement, compound 3: 13-fold (1.10 log units) below; measured number outside the range, above it.
By their numbers in this assay, from the lowest: compound 2; then compound 1; then compound 3.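

Isopropyl in place of fluoro gives a 110-fold higher number from compound 2 to compound 3 (2.06 log units; beyond the scatter), a step that reaches well past the one seen between the two halogen-bearing groups. Isopropyl in place of trifluoromethyl gives a 7.6-fold higher number from compound 1 to compound 3 (0.88 log units; beyond the scatter), so compound 3 has the highest number of the three, and this position separates the all-carbon isopropyl from both fluorine-bearing groups. No supporting data account for the size of these steps. The compounds shown leave open where a methyl group, a methoxy group or an amine would fall at this position.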